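From benzyl to 4-methoxybenzyl in compound 2

This account rests on a few compounds, and the source may have more. Where it says the series, first, only, none or still open, it means among the compounds named here.

In a functional assay on SK-OV-3 cells (Homo sapiens) for cytotoxicity, read by MTT assay, with a stated time of 48 h (on this read-out higher numbers stand for weaker inhibition and lower numbers for stronger inhibition), compound 1 `CN(C)CCCCCCN(C)C1=Nc2ccccc2C(CC(=O)NCc2ccccc2)N1c1ccc(-c2ccccc2)cc1` gives 5780 nM and compound 2 `CN(C)CCN1CCN(C2=Nc3ccccc3C(CC(=O)NCc3ccccc3)N2c2ccc(-c3ccccc3)cc2)CC1` gives 1970 nM. That side-chain exchange (a 2.9-fold lower number from compound 1 to compound 2 (0.47 log units; beyond the scatter)) lies elsewhere in the molecule and offers little guidance here. Compound 2 stands at the low end of the three numbers alongside compound 3 `Cc1ccc(CNC(=O)CC2c3ccccc3N=C(N3CCN(CCN(C)C)CC3)N2c2ccc(-c3ccccc3)cc2)cc1` at 2330 nM and the two lie within the scatter of each other. Compound 4 `COc1ccc(CNC(=O)CC2c3ccccc3N=C(N3CCN(CCN(C)C)CC3)N2c2ccc(-c3ccccc3)cc2)cc1` has methoxy in place of hydrogen on an aromatic carbon, benzyl to 4-methoxybenzyl (methoxy in place of hydrogen on an aromatic carbon). The nearest guide is the methyl change in compound 3 (a 1.2-fold higher number from compound 2 to compound 3 (0.07 log units; within the scatter)) at that same place, so no step beyond the scatter is expected in this assay for methoxy. The expected step is small (a 1.1-fold higher number from compound 2 to compound 4 (0.03 log units; within the scatter)). Compound 4 is estimated at 2100 nM (range 1100 nM to 4000 nM).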

Compound 4, half-maximal inhibitory concentration: 2470 nM
The estimate for compound 4 lay 1.2-fold (0.07 log units) below the measured number; the measured number falls inside the stated range.
By their numbers in this assay, from the lowest: compounds 2, 3 and 4 (each within the scatter of the next); then compound 1.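

Going from benzyl to 4-methoxybenzyl in this assay shows that this aromatic carbon also carries methoxy without a step beyond the scatter (a 1.3-fold higher number from compound 2 to compound 4 (0.10 log units; within the scatter)). Methoxy and methyl cannot be told apart here either (a 1.1-fold higher number from compound 3 to compound 4 (0.03 log units; within the scatter)), so compound 2, compound 3 and compound 4 form one level, which methyl alone could not show. Nothing at hand explains why this position gives so little response.

On these data alone, whether an amine, a carboxylic acid or a longer chain at this place would move the number remains open. So does whether methoxy would give the same result with the side chain of compound 1.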